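The source may report more compounds than this note shows. Statements on the series, on what has been measured and on what is new or still open speak of the compounds shown alone.

Compound 1 `Cc1ccc(C(=O)N/N=C/c2ccccc2)c(O)c1` is the starting point of this comparison. In a functional assay (Mus musculus, strain BALB/C) for inhibition, read by MTT assay, with stated times of 24 h and 72 h (on this read-out lower numbers stand for stronger inhibition and higher numbers for weaker inhibition), compound 1 gives 53900 nM, the higher of the two plain numbers available, so among those two it is the weaker inhibitor. Compound 3 `Cc1ccc(C(=O)N/N=C/c2ccccc2Cl)c(O)c1` gives 19200 nM in this assay, and the step is a 2.8-fold lower number from compound 1 to compound 3 (0.45 log units; beyond the scatter). Compound 2 `Cc1ccc(C(=O)N/N=C/c2ccccc2[N+](=O)[O-])c(O)c1` reaches only > 100000 nM in this assay, which is a limit of the assay rather than a number. This is the limit of > 100000 nM in this assay, at which 1 of the 3 values shown sits. From compound 1 the change to compound 2 is an at least 1.8-fold higher number from compound 1 to compound 2 (0.26 log units; that floor lies within the scatter).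

Compound 4 `COc1ccc(/C=N/NC(=O)c2ccc(C)cc2O)cc1` has not been measured yet. Compared with compound 1 it carries methoxy in place of hydrogen on an aromatic carbon. Within the data shown here, two measured steps bear on this change, since each also places a group on an aromatic carbon of the same ring: chloro brought a 2.8-fold lower number from compound 1 to compound 3 (0.45 log units; beyond the scatter), while nitro brought an at least 1.8-fold higher number from compound 1 to compound 2 (0.26 log units; that floor lies within the scatter). Methoxy is neither of these groups, and the two steps point in opposite directions, so no firm direction follows from them. A step that stays within the scatter is therefore the most reasonable expectation. Compound 4 is expected to give about 45000 nM, with a range from 18000 nM to 110000 nM. That estimate means a 1.2-fold lower number from compound 1 to compound 4 (0.08 log units; within the scatter), a step expected to remain inside the scatter.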

Compound 4, half-maximal inhibitory concentration: > 100000 nM
Compound 4: no number, only a limit; the forecaster's own chance of this, stated with the estimate: 20%; middle value at least 2.2-fold (0.34 log units) from the limit.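

Compound 4 gives a limit and not a number in this assay. The change therefore reads only as an at least 1.8-fold higher number from compound 1 to compound 4 (0.26 log units; that floor lies within the scatter), and since that floor stays within the scatter, methoxy in place of hydrogen, para to a large group, cannot be said to have moved the result away from that of compound 1, although it clearly brings no gain of the kind seen with chloro. Of the three groups now tried on this ring, only chloro, in compound 3, has given a lower number than compound 1 beyond the scatter, while compound 2 and compound 4 both go against any idea that adding a group to this ring helps in general, and they end at the same ceiling: the limit of > 100000 nM in this assay, at which 2 of the 4 values shown sit.

The two compounds at that limit cannot be ranked against each other, so the compounds shown do not tell whether nitro and methoxy truly differ. As far as these compounds go, it also stays open how a small amine or a hydroxy group would read at this same place, and whether chloro would keep its lower number if it sat where the methoxy of compound 4 sits.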